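Alpha-ketooxazole series: iodo replacing the carboxypyridinyl substituent

The source may hold more compounds than are shown below. What is called first, only, known or untested is meant among the compounds shown, and "the series" means these compounds.

Measured compounds:
compound 1 `O=C(O)c1ccc(-c2cnc(C(=O)CCc3ccc(Oc4ccccc4)cc3)o2)nc1`, 33 nM
compound 2 `O=C(O)c1ccc(-c2cnc(C(=O)CCc3ccc(COc4ccccc4)cc3)o2)nc1`, 4.6 nM

Compound 1 is the weaker of the two measured inhibitors in an assay for inhibition of Fatty-acid amide hydrolase 1 (Rattus norvegicus); a higher number here means a weaker inhibitor, a lower number a stronger inhibitor; its nearest neighbour is compound 2, and the step of a 7.2-fold lower number from compound 1 to compound 2 (0.86 log units; beyond the scatter) concerns only the linker on the distal aryl ring, phenoxymethyl in place of phenoxy.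

Compound 3 `O=C(CCc1ccc(Oc2ccccc2)cc1)c1ncc(I)o1` keeps the phenoxy linker of compound 1 and changes the other end of the shared core: iodo in place of 5-carboxypyridin-2-yl on an aromatic carbon. The group that leaves is the only aryl acid in the pair; what enters is a single iodine on the five-membered ring, next to the ring oxygen.

For the measured compounds named here, no measured step bears on this position. Going by the values given here, the one step in hand, from compound 1 to compound 2, is at the opposite end of the molecule and gives no guidance on the size or direction of this change. Removal of a group of this size, and of both its hydrogen-bond donor and acceptors, is expected to cost potency, but the amount is uncertain and the range set wide. Compound 3 is estimated at 120 nM (range 25 nM to 600 nM), an expected step of a 3.6-fold higher number from compound 1 to compound 3 (0.56 log units; beyond the scatter).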

Compound 3, inhibition constant: 10 nM
Beside the measured number, compound 3's estimate is 12-fold (1.08 log units) above it; measured number below the stated range.
By their numbers in this assay, from the lowest: compound 2; then compound 3; then compound 1.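

In this assay, the 5-carboxypyridin-2-yl group is not needed for potency at this position when the phenoxy linker is held constant: replacing it with iodo on the same aromatic carbon, next to the ring oxygen, gives a 3.3-fold lower number from compound 1 to compound 3 (0.52 log units; beyond the scatter) in the direction of stronger inhibition. The position therefore accepts a single iodine atom in place of a group of 9 heavy atoms, and the aryl acid, with its 1 hydrogen-bond donor and 2 hydrogen-bond acceptors, can be lost here without any cost in this read-out. Nothing in hand accounts for this direction of change.

As far as these compounds go, whether iodo gives a step of similar size and direction on the phenoxymethyl linker of compound 2 remains open, since that pairing would test whether the two ends of the molecule act independently. Also open, from the compounds shown here alone, is how far the result depends on iodine itself: hydrogen, chloro, bromo, a methyl group or a carboxylic acid placed directly on this carbon would show whether a small substituent in general serves as well here.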